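Brine shrimp toxicity in a tolyl-sulfonylurea chalcone series

The source may report more compounds than this note shows. Statements on the series, on what has been measured and on what is new or still open speak of the compounds shown alone.

Compound 1 `COc1ccc(/C=C/C(=O)c2ccccc2NC(=O)NS(=O)(=O)c2ccc(C)cc2)c(OC)c1` gives 16 ug/mL in an ADME assay on the whole organism for cytotoxicity, with Artemia salina as the target, with a stated time of 24 h; on this read-out higher numbers stand for an effect only at larger amounts of compound and lower numbers for an effect already at smaller amounts.
Compound 2 `Cc1ccc(S(=O)(=O)NC(=O)Nc2ccccc2C(=O)/C=C/c2cccc(O)c2)cc1` gives 39.3 ug/mL in this assay.
Compound 3 `Cc1ccc(S(=O)(=O)NC(=O)Nc2ccccc2C(=O)/C=C/c2ccc(F)cc2)cc1` gives 3.96 ug/mL in this assay.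

Compound 2 holds the highest of the three numbers in this assay: compound 1 is nearest, a 2.5-fold higher number from compound 1 to compound 2 (0.39 log units; beyond the scatter), and compound 3 is furthest, a 9.9-fold lower number from compound 2 to compound 3 (1.00 log units; beyond the scatter). Compound 4 `Cc1ccc(S(=O)(=O)NC(=O)Nc2ccccc2C(=O)/C=C/c2ccc(Cl)cc2)cc1` has not yet been measured; it differs from compound 2 in one place, (4-chlorophenyl in place of 3-hydroxyphenyl on a double-bonded chain carbon bound to a double-bonded chain carbon).

Going by the values given here, the step that bears most directly on this change is the one from compound 2 to compound 3, which also exchanges the 3-hydroxyphenyl for a halogen-bearing phenyl on the same double-bonded chain carbon and reads a 9.9-fold lower number from compound 2 to compound 3 (1.00 log units; beyond the scatter). The step of a 4.0-fold lower number from compound 1 to compound 3 (0.61 log units; beyond the scatter) points the same way, and a 2.5-fold higher number from compound 1 to compound 2 (0.39 log units; beyond the scatter) places the 3-hydroxyphenyl member at the top. On this basis a lower number is expected for compound 4 in this assay, of a size close to the step to compound 3, a 9.8-fold lower number from compound 2 to compound 4 (0.99 log units; beyond the scatter). Whether the 4-chlorophenyl member sits slightly above or below the 4-fluorophenyl member cannot be told from these three compounds. Compound 4 is estimated at 4 ug/mL in this assay, within 1.5 ug/mL to 12 ug/mL.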

Compound 4, concentration for half-maximal effect: 6.92 ug/mL
For compound 4 the middle estimate is 1.7-fold (0.24 log units) below the measured one; measured number inside the range.
By their numbers in this assay, from the lowest: compounds 3 and 4 (each within the scatter of the next); then compound 1; then compound 2.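

In this assay a second halogen-bearing phenyl also reads far below the 3-hydroxyphenyl member (a 5.7-fold lower number from compound 2 to compound 4 (0.75 log units; beyond the scatter)), so the drop at this place, on a double-bonded chain carbon bound to a double-bonded chain carbon, is not confined to 4-fluorophenyl. The step for chloro in place of fluoro on an aromatic carbon (a 1.7-fold higher number from compound 3 to compound 4 (0.24 log units; within the scatter)) stays within the scatter, so the two halogen-bearing members cannot be told apart here. Going by these compounds alone, the 4-chlorophenyl member also reads lower than the 2,4-dimethoxyphenyl member (a 2.3-fold lower number from compound 1 to compound 4 (0.36 log units; beyond the scatter)), which places both halogen-bearing phenyls under both oxygen-bearing phenyls in this set of four, with no compound going against that split.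

Nothing given here accounts for these steps. Still open, as far as these compounds go, is whether an unsubstituted phenyl, or a phenyl carrying an amine or a carboxylic acid, would read with the halogen-bearing members or with the oxygen-bearing ones, and whether 3-chlorophenyl would read with 4-chlorophenyl, which would separate the effect of the halogen from that of its place on the ring.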